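The compounds below may be only part of what the source reports. "The series", "measured", "known", "first", "only" and "open" are said of these compounds alone.

Compound 1 `Cc1oc2c3c(ccc2c(=O)c1C)OC[C@H]1[C@@H]3C2=C(CCCC2=O)OC1(C)C` was tested in a functional assay on SK-N-SH cells (Homo sapiens) for antiproliferative activity, read by MTT assay, with a stated time of 48 h (a lower number here means a stronger inhibitor, a higher number a weaker inhibitor), and in this assay compound 1 reached only a limit of > 100000 nM. Compound 2 `Cc1coc2c3c(ccc2c1=O)OC[C@H]1[C@@H]3C2=C(CCCC2=O)OC1(C)C` differs by hydrogen in place of methyl on an aromatic carbon. In this assay compound 2 likewise reached only a limit of > 100000 nM. The step that the two limits leave unreadable from compound 1 to compound 2 cannot be sized because of the limit of > 100000 nM in this assay, at which 2 of the 2 values shown sit. Compound 3 `Cc1oc2c3c(ccc2c(=O)c1-c1ccccc1)OC[C@H]1[C@@H]3C2=C(CCCC2=O)OC1(C)C` carries the change (phenyl in place of methyl on an aromatic carbon). For the measured compounds named here, no measured step shows any gain from such a change, so in this assay compound 3 is expected at 120000 nM, in a range from 25000 nM to 600000 nM. For compound 3 the expected step is a step that the limit leaves unreadable from compound 1 to compound 3.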

Compound 3, half-maximal inhibitory concentration: > 100000 nM
Compound 3: a limit, no number; the forecaster's own chance of this, stated with the estimate: 80%; the middle value does not contradict the limit.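

For the compounds shown here, no step from compound 1 to compound 3 can be read, because both compounds reach only a limit, not a number: the limit of > 100000 nM in this assay, at which 3 of the 3 values shown sit. Compound 1, compound 2 and compound 3 leave open whether changing the group at this place alters activity at all.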